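Swapping the aryl for cyclopentyl on an inactive quinazoline

The compounds below may be only part of what the source reports. "The series", "measured", "known", "first", "only" and "open" are said of these compounds alone.

The series is built on a shared core carrying a benzylamine arm and a group at the position between two ring nitrogens. Compound 1 `FC(F)(F)c1ccc(CNc2nc(-c3ccccc3C(F)(F)F)nc3ccccc23)cc1` is measured in an assay on a protein complex for inhibition of ubiquitin carboxyl-terminal hydrolase 1/WD repeat-containing protein 48 (Homo sapiens), read by fluorescence (a lower number here means a stronger inhibitor, a higher number a weaker inhibitor), at 8900 nM, and compound 2 `FC(F)(F)c1ccccc1-c1nc(NCc2ccc(-c3cccc(Cl)c3)cc2)c2ccccc2n1` in this assay at 2700 nM. Within the data shown here, the one step that links two measured compounds, a 3.3-fold lower number from compound 1 to compound 2 (0.52 log units; beyond the scatter), concerns the far end of the benzylamine arm and not the group at the core. Compound 3 `FC(F)(F)c1ccc(-c2nc(NCc3ccc(-c4cccnc4)cc3)c3ccccc3n2)cc1` carries a pyridyl on that arm and is reported in this assay as "not active" (no number reported), so no number places it against compounds 1 and 2.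

Compound 4 `c1cncc(-c2ccc(CNc3nc(C4CCCC4)nc4ccccc34)cc2)c1` differs from compound 3 in a single place: cyclopentyl in place of 4-(trifluoromethyl)phenyl on an aromatic carbon. Among the measured compounds shown here, no measured step touches that position, and compound 3 itself gives no number to anchor a change, so the only expectation that can be drawn is that compound 4 is likely to remain a weak inhibitor, with a real chance that this assay again reports only a limit. On that basis compound 4 is estimated at 15000 nM, within a range of 3000 nM to 80000 nM.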

Compound 4, half-maximal inhibitory concentration: "not active" (no number reported)
The entry for compound 4 holds no number, and the estimate cannot be compared.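

Compound 3 and compound 4 are both reported as "not active" in this assay, with no number for either, so no step can be read between them. Nothing shown here bears on this result. The compounds shown leave open how cyclopentyl and 4-(trifluoromethyl)phenyl compare in strength of inhibition at this place on the shared core.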